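The source may report more compounds than this note shows. Statements on the series, on what has been measured and on what is new or still open speak of the compounds shown alone.

Among the measured compounds shown here, compound 1 `CCCCC(O)c1ccc(CN(CCCCCCC(=O)O)S(C)(=O)=O)cc1` is the only member of this small group with a number in a functional assay on HEK293 cells for agonist activity at prostaglandin E2 receptor EP2 subtype (Rattus norvegicus), read by cAMP accumulation (a higher number here means that more compound is needed for the effect, a lower number that less compound is needed), where compound 1 gives 423 nM. Two further compounds, compound 2 `CCCCc1ccc(CN(CCCOc2cccc(C(=O)O)c2)S(C)(=O)=O)cc1` and compound 3 `CC(C)(C)c1ccc(CN(Cc2cccc(CCC(=O)O)c2)S(=O)(=O)c2ccc(Cl)cc2)cc1`, have no result: in this assay compound 2 is recorded as "not determined" (no result reported) and compound 3 as "not determined" (no result reported). Compound 4 `CCCCCC(O)c1ccc(CN(CCCCCCC(=O)O)S(C)(=O)=O)cc1` has not yet been tested. It differs from compound 1 in one place: methyl in place of hydrogen on a saturated chain carbon, five bonds along the chain from an aromatic carbon and an oxygen on a saturated carbon. For the measured compounds named here, no measured pair shows what such a change does, so there is no basis for expecting a shift beyond the usual scatter in either direction. The expected step from compound 1 to compound 4 is accordingly small, a 1.1-fold lower number from compound 1 to compound 4 (0.05 log units; within the scatter). Compound 4 is expected to give about 380 nM, within a range from 120 nM to 1200 nM.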

Compound 4, half-maximal effective concentration: 44 nM
Estimate against measurement, compound 4: 8.6-fold (0.94 log units) above; measured number below the stated range.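

This position is not indifferent: in this assay, methyl in place of hydrogen on this saturated chain carbon gives a 9.6-fold lower number from compound 1 to compound 4 (0.98 log units; beyond the scatter), a step beyond the scatter from a single added carbon. Among the compounds shown here, it is the first measured step in this group, and it shows that the number responds to the length of this chain. Nothing available here accounts for the size of the step. As far as these compounds go, whether a longer chain than that of compound 4 would lower the number further remains open. So does the outcome of placing an amine or a fluorine on this same carbon.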